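Swapping the amine at the end of the side chain

A few compounds are considered here, and "the series" means these few. Any claim that something is new, unique, unknown or untested is made for them only; others in the source may bear on it.

Measured compounds:
compound 1 `O=c1cc(-c2ccccc2)oc2cc(O)c(OCCCCN3CCCCC3)c(O)c12` — 75000 nM
compound 2 `COc1cc2oc(-c3ccccc3)cc(=O)c2c(O)c1OCCCCN1CCN(C)CC1` — 32000 nM

In a functional assay on A549 cells (Homo sapiens) for antiproliferative activity, read by MTT assay, with a stated time of 48 h (on this read-out lower numbers stand for stronger inhibition and higher numbers for weaker inhibition), compound 2 gives 32000 nM, the lower of the two numbers, while compound 1 gives 75000 nM, a gap beyond the usual scatter. These two compounds differ in several places, so no single change can be read from them. Compound 3 `COc1cc2oc(-c3ccccc3)cc(=O)c2c(O)c1OCCCCN1CCCCC1` differs from compound 2 in one place: piperidin-1-yl in place of 4-methylpiperazin-1-yl on a saturated chain carbon, four bonds along the chain from an oxygen on an aromatic ring. For the measured compounds named here, no measured pair isolates this change. The step is expected to stay within the scatter, a 1.3-fold higher number from compound 2 to compound 3 (0.10 log units; within the scatter), with no clear direction. Compound 3 is estimated at 40000 nM, within a range from 15000 nM to 110000 nM.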

Compound 3, half-maximal inhibitory concentration: 34000 nM
Compound 3: middle estimate off by 1.2-fold (0.07 log units), on the high side; measured number inside the range.
By their numbers in this assay, from the lowest: compounds 2 and 3 (each within the scatter of the next); then compound 1.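

In this assay, piperidin-1-yl in place of 4-methylpiperazin-1-yl gives a 1.1-fold higher number from compound 2 to compound 3 (0.03 log units; within the scatter), so the two ring amines at the end of this chain cannot be told apart. Methyl in place of hydrogen on an oxygen on an aromatic ring gives a 2.2-fold lower number from compound 1 to compound 3 (0.34 log units; beyond the scatter) and is the only single change here that moves the number beyond the scatter. Nothing measured here explains either step. Still open, on these data alone, is whether morpholine, an open-chain amine such as diethylamine, or a shorter chain would also leave the number unmoved.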